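One Methyl on an Aromatic Nitrogen, Seen Twice

The source may report more compounds than this note shows. Statements on the series, on what has been measured and on what is new or still open speak of the compounds shown alone.

Compound 1 `COc1ccc2[nH]c(C)c(Cc3ccccc3)c(=O)c2c1` and compound 2 `COc1ccc2c(=O)c(Cc3ccccc3)c(C)[nH]c2c1` are made of the same atoms joined differently; the difference between the two cores is not broken down here. In an ADME assay for permeability, using PAMPA, at pH 7.4 (on this read-out lower numbers stand for lower permeability and higher numbers for higher permeability), compound 1 gives 188 10^-6 cm/s and compound 2 gives 240 10^-6 cm/s, two numbers within the scatter of each other. Compound 3 `COc1ccc2c(c1)c(=O)c(Cc1ccccc1)c(C)n2C` differs from compound 1 by a single change: methyl in place of hydrogen on an aromatic nitrogen. In this assay compound 3 gives 268 10^-6 cm/s, so that a 1.4-fold higher number from compound 1 to compound 3 (0.15 log units; within the scatter). Compound 4 `COc1ccc2c(=O)c(Cc3ccccc3)c(C)n(C)c2c1` carries the same change relative to compound 2: methyl in place of hydrogen on an aromatic nitrogen. For compound 4 a step of a 1.3-fold higher number from compound 2 to compound 4 (0.11 log units; within the scatter) in this assay is expected, resting on the one earlier occurrence of this change, which gave a 1.4-fold higher number from compound 1 to compound 3 (0.15 log units; within the scatter). Compound 4 is therefore estimated at 310 10^-6 cm/s in this assay, with a likely range from 200 10^-6 cm/s to 480 10^-6 cm/s.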

Compound 4, apparent permeability: 299 10^-6 cm/s
Compound 4: the middle estimate sits 1.0-fold (0.02 log units) above what was measured; the range from low to high includes it.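

In this assay, methyl in place of hydrogen on an aromatic nitrogen gives a 1.2-fold higher number from compound 2 to compound 4 (0.10 log units; within the scatter), and this step agrees with the earlier one on the other core: the same change on two cores in this assay, a 1.4-fold higher number (0.15 log units; within the scatter) from compound 1 to compound 3 and a 1.2-fold higher number (0.10 log units; within the scatter) from compound 2 to compound 4, 1.1-fold (0.06 log units) apart, within the scatter of two such steps

Within these two cores, then, the change carries over with much the same small size. Each step lies within the scatter, however, so the pair does not show that the methyl really moves the number, and two cores cannot show that the same would hold on any other core.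

The compounds shown leave open what a longer chain on the aromatic nitrogen would give in this assay. They also leave open whether a carboxylic acid or an amine in place of the benzyl group would alter how this change carries over.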